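Phenyl ester imine series on breast cancer cells: acyl removal

The source may hold more compounds than are shown below. What is called first, only, known or untested is meant among the compounds shown, and "the series" means these compounds.

Measured compounds in a functional assay on MDA-MB-231 cells (Homo sapiens) for cytotoxicity; a lower number here means a stronger inhibitor, a higher number a weaker inhibitor:
compound 1 `CCCCCCCCCCCCCCCCCC(=O)Oc1ccc(/C=N/Cc2cccnc2)cc1` gives 11500 nM
compound 2 `CCCCCCC(=O)Oc1ccc(/C=N/Cc2cccnc2)cc1` gives 15000 nM
compound 3 `CCCCCCCCCCCC(=O)Oc1ccc(/C=N/Cc2cccnc2)cc1` gives 18900 nM

The three measured compounds share one core and differ only in the length of the ester chain. Compound 2 stands second highest of the three numbers; the step to its nearest neighbour is a 1.3-fold higher number from compound 2 to compound 3 (0.10 log units; within the scatter), and the step from its furthest neighbour is a 1.3-fold higher number from compound 1 to compound 2 (0.12 log units; within the scatter). The remaining step, a 1.6-fold higher number from compound 1 to compound 3 (0.22 log units; within the scatter), is likewise within the scatter, so the chain length has no resolved effect on cytotoxicity in this assay across compounds 1, 2 and 3.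

Compound 4 `Oc1ccc(/C=N/Cc2cccnc2)cc1` differs from compound 2 by hydrogen in place of hexylcarbonyl on an oxygen on an aromatic ring. Going by the values given here, no measured step bears on this change: every step so far keeps the ester and alters only the chain, and none moves beyond the scatter. There is therefore no basis for a directional expectation, and the estimate for compound 4 is placed near the cluster of measured values with a wide range. The expected step is a 1.3-fold higher number from compound 2 to compound 4 (0.12 log units; within the scatter). For compound 4 the estimated value is 20000 nM, expected to fall between 6000 nM and 70000 nM.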

Compound 4, half-maximal inhibitory concentration: 16900 nM
Beside the measured number, compound 4's estimate is 1.2-fold (0.07 log units) above it; low and high end bracket the measured number.
By their numbers in this assay, from the lowest: compounds 1, 2, 4 and 3 (each within the scatter of the next).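

Hydrogen in place of hexylcarbonyl on an oxygen on an aromatic ring gives a 1.1-fold higher number from compound 2 to compound 4 (0.05 log units; within the scatter) in this assay. The earlier steps shown here all kept the ester and altered only the chain; this step takes away the entire acyl group, and compound 4 still stays within the scatter of compound 2, so neither the chain nor the carbonyl attached to this oxygen has a resolved effect on the number here. Nothing available explains this result.

Still open, as far as these compounds go, is whether another group on this oxygen, such as acetyl, a methyl ether or a chain ending in a carboxylic acid, would move the number beyond the scatter. Also open, from the compounds shown here alone, is whether a change in the shared core, such as an amine in place of the imine, would do so.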